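The source may hold more compounds than are shown below. What is called first, only, known or untested is meant among the compounds shown, and "the series" means these compounds.

Measured so far in a functional assay on the whole organism (B cells) with Mus musculus as the target; on this read-out lower numbers stand for smaller maximal responses and higher numbers for larger maximal responses:
- Compound 1 `Nc1nc(O)c2c(n1)n(C1OC(CO)[C@@H](O)[C@H]1O)c(=O)n2CC(O)CSc1ccccc1` gives 12%
- Compound 2 `C=CCSc1nc2c(O)nc(N)nc2n1C1OC(CO)[C@@H](O)[C@H]1O` gives 107%
- Compound 3 `C=CCn1c(=O)n(Cc2ccccc2)c2nc(N)nc(O)c21` gives 25%

Among these three, compound 1 stands lowest. Its nearest neighbour is compound 3, whose maximal response lies higher by a margin beyond the usual scatter, while compound 2 lies furthest away, its far larger maximal response also beyond the scatter. Going by the values given here, no single-point step between two measured compounds is available here, so the move from compound 1 to compound 4 `NC(=O)Cn1c(=O)n(C2OC(CO)[C@@H](O)[C@H]2O)c2nc(N)nc(O)c21` has to be judged from the structures alone.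

The change is carbamoyl in place of 1-hydroxy-2-(phenylsulfanyl)ethyl on a saturated chain carbon bound to an aromatic nitrogen. The shared core of compound 1 is kept unchanged.

Among the compounds with values here, with no measured step to lean on, only a cautious expectation can be given. Compound 4 is expected to remain in the low range, because compound 1 gives 12% and compound 3, which carries the same core, gives 25%. The step from compound 1 to compound 4 is therefore expected to be small, an estimated a number 8 percentage points higher from compound 1 to compound 4 (within the scatter), possibly within the scatter. Compound 4 is estimated at 20%, with a range from 5% to 50%.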

Compound 4, largest response reached (reported as maximal response), in percent of the reference or control that the assay uses: 32%
Compound 4: middle estimate off by 12 percentage points, on the low side; the range from low to high includes it.
By their numbers in this assay, from the lowest: compound 1; then compounds 3 and 4 (each within the scatter of the next); then compound 2.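

In this assay, going by these compounds alone, carbamoyl in place of 1-hydroxy-2-(phenylsulfanyl)ethyl on a saturated chain carbon bound to an aromatic nitrogen gives a modest rise, a number 20 percentage points higher from compound 1 to compound 4 (beyond the scatter), and this is the first single change that can be read directly. The step shows that this position responds to the exchange, yet a group of 10 heavy atoms with a six-membered aromatic ring of carbon only can give way to a group of 3 heavy atoms with no ring while compound 4 still reaches only 32%. Nothing available explains why the maximal response moves in this direction.

Within the data shown here, the single step leaves open whether the rise follows from the loss of the phenylsulfanyl part, the loss of the hydroxyl or the arrival of carbamoyl, as all three changes occur together. As far as these compounds go, it also remains open how a carboxylic acid, a primary amine or a longer chain ending in carbamoyl would behave on the same saturated chain carbon, with the shared core kept unchanged.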